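Sulfamate series: amine replacement at the meta position of compound 1

The source may hold more compounds than are shown below. What is called first, only, known or untested is meant among the compounds shown, and "the series" means these compounds.

Within the data shown here, the two measured members share one core carrying the sulfamate. Compound 1 is `CCN(Cc1ccc(Br)cc1)c1cccc(C(=O)N2CCc3ccc(OS(N)(=O)=O)cc3C2)c1` and compound 2 is `CCN(Cc1ccc(Br)cc1)c1ccc(C(=O)N2CCc3ccc(OS(N)(=O)=O)cc3C2)cc1`. In an assay on HEK293 cells for inhibition of Steryl-sulfatase (Homo sapiens), tested at 1 uM (a lower number here means a weaker effect, a higher number a stronger effect of the compound at the concentration tested), compound 1 gives 84.5%, while compound 2 gives 95.9%; compound 1 thus stands lowest of the two numbers, and the gap to compound 2 lies beyond the scatter.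

The next member is compound 3, `CN(C)CCN(CCN(C)C)c1cccc(C(=O)N2CCc3ccc(OS(N)(=O)=O)cc3C2)c1`. Compared with compound 1 the change is bis(2-(dimethylamino)ethyl)amino in place of (4-bromobenzyl)(ethyl)amino on an aromatic carbon. Among the measured compounds shown here, no step between measured compounds speaks to this exchange, so the direction can only be judged from compound 1 itself, whose value 84.5% leaves room to fall. A step downward beyond the scatter is expected, from compound 1 to compound 3 a number 19.5 percentage points lower from compound 1 to compound 3 (beyond the scatter). For compound 3 the estimate in this assay is 65%, with a likely range from 35% to 90%.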

Compound 3, a percentage reported as inhibition, at one concentration (the size of the read-out at that concentration, not a potency): 17.1%
The estimate for compound 3 lay 47.9 percentage points above the measured number; measured number outside the range, below it.
By their numbers in this assay, from the lowest: compound 3; then compound 1; then compound 2.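

At this position, on an aromatic carbon meta to a large group, the substituent strongly affects the read-out: in this assay, bis(2-(dimethylamino)ethyl)amino in place of (4-bromobenzyl)(ethyl)amino gives a large drop (a number 67.4 percentage points lower from compound 1 to compound 3 (beyond the scatter)). Both groups have 11 heavy atoms, so the drop occurs with no change in that count; the exchange removes the six-membered aromatic ring and the bromine and raises the hydrogen-bond acceptors from 1 to 3. No supporting measurement bears on this result, and which of these differences matters remains unresolved.

Still open, as far as these compounds go, is whether a plain benzyl group without the bromine, or a single 2-(dimethylamino)ethyl chain paired with the 4-bromobenzyl group, would retain the level of compound 1 (84.5%). Also open, from the compounds shown here alone, is whether bis(2-(dimethylamino)ethyl)amino would give a similar drop at the attachment found in compound 2.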